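A few compounds are considered here, and "the series" means these few. Any claim that something is new, unique, unknown or untested is made for them only; others in the source may bear on it.

Measured compounds:
- compound 1, `C#CCNC1CCc2c(SCc3ccc(Cl)cc3Cl)cccc21`, 22300 nM
- compound 2, `C#CCNC1CCc2c(SCc3cccc(C)c3)cccc21`, > 100000 nM
- compound 3, `C#CCNC1CCc2c(SCCc3cccc(Br)c3)cccc21`, 620 nM

Of the compounds shown here, three that share a core have been tested in an ADME assay on isolated protein for inhibition of Amine oxidase [flavin-containing] B (Homo sapiens); a higher number here means a weaker inhibitor, a lower number a stronger inhibitor. Compound 1 gives 22300 nM in this assay. Compound 3 gives 620 nM in this assay. For compound 2 the assay reports only a limit, > 100000 nM, so where compound 2 stands among the three is known only as a limit, and it sits at the limit of > 100000 nM in this assay, at which 1 of the 3 values shown sits.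

Compound 4, `C#CCNC1CCc2c(SCc3cccc(OC)c3)cccc21`, has not yet been measured in this assay. It differs from compound 2 in a single place: methoxy in place of methyl on an aromatic carbon. Among the compounds with values here, since compound 2 is known only as a limit, no measured step in this assay says how this change acts. The expectation is that the step of a number no higher from compound 2 to compound 4 (the limit leaves the size open) is small and does not go beyond the usual scatter in either direction. Compound 4 is therefore expected to give about 100000 nM in this assay, within a range from 30000 nM to 300000 nM, with a fair chance that only a limit is reported again.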

Compound 4, half-maximal inhibitory concentration: 1520 nM
Compound 4: the middle estimate sits 66-fold (1.82 log units) above what was measured; measured number below the stated range.
By their numbers in this assay, from the lowest: compound 3; then compound 4; then compound 1. At a limit, above all of these: compound 2.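

In this assay, methoxy in place of methyl on an aromatic carbon, meta to a large group, gives an at least 65-fold lower number from compound 2 to compound 4 (1.81 log units; beyond the scatter). Within the data shown here, this is the first step between compounds that differ in one place, and it shows that the number responds strongly to the group at this position, which compounds 1 and 3 could not show. The full size of the step stays unknown, since compound 2 is reported only as a limit: the limit of > 100000 nM in this assay, at which 1 of the 4 values shown sits.

The compounds shown leave open whether an ethoxy group, a hydroxyl group or an amine at this position would give a number like that of compound 4. Among these compounds, they also leave open whether the same change would act alike on compounds with a different chain, as no step links compound 1 or compound 3 to the others.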